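Geometry of the Oxime: Compound 3 to Compound 4

This account rests on a few compounds, and the source may have more. Where it says the series, first, only, none or still open, it means among the compounds named here.

Of the compounds shown here, three sharing one core have been measured in a functional assay on HEK293 cells with D(4) dopamine receptor (Homo sapiens) as the target, read by FLIPR; a lower number here means that less compound is needed, a higher number that more compound is needed for the effect. Compound 1 `O/N=C(/CCN1CCN(c2ccccn2)CC1)c1ccccc1` gives 21.7 nM. Within the data shown here, compound 2 `O/N=C(/CCN1CCN(c2ccccn2)CC1)c1ccccc1Cl` gives 25 nM, and the move a 1.2-fold higher number from compound 1 to compound 2 (0.06 log units; within the scatter) is the only single-point step among the measured compounds; it changes nothing beyond the usual scatter. Among the measured compounds shown here, compound 3 `O/N=C(\CCN1CCN(c2ccccn2)CC1)c1cc(F)cc(F)c1` gives 19.4 nM, a number that sits alongside those of compound 1 and compound 2, each gap being within the usual scatter, so no compound of the three can be set apart from the others.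

Compound 4 `O/N=C(/CCN1CCN(c2ccccn2)CC1)c1cc(F)cc(F)c1` is the untested partner of compound 3. The difference is the two compounds have the same atoms and bonds and differ only in configuration as drawn: 1 of 1 stereo elements differ; a double bond is drawn E in compound 3 and Z in compound 4. For the measured compounds named here, no measured step addresses a change of this kind: the one available step, from compound 1 to compound 2, concerns a substituent on an aromatic carbon and says nothing about the geometry of the double bond. The measured series therefore offers no ground for predicting a shift in either direction, and the working expectation is that compound 4 lands near compound 3, with the step of a 1.1-fold higher number from compound 3 to compound 4 (0.05 log units; within the scatter) expected to stay within the scatter. Compound 4 is accordingly estimated at 22 nM, with a range from 8 nM to 60 nM, the range kept wide since nothing measured here constrains it.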

Compound 4, half-maximal effective concentration: 17.5 nM
Estimate against measurement, compound 4: 1.3-fold (0.10 log units) above; the measured number falls inside the stated range.
By their numbers in this assay, from the lowest: compounds 4, 3, 1 and 2 (each within the scatter of the next).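

In this assay the geometry of the oxime double bond can now be read directly: with the 3,5-difluorophenyl group held in place, the change from E to Z as drawn gives a 1.1-fold lower number from compound 3 to compound 4 (0.04 log units; within the scatter), and this reading rests on a single clean difference: the fact that compounds 3 and 4 differ only in the configuration as drawn. Among these compounds, compound 4 also allows the first comparisons of the aromatic group at one drawn geometry, with 3,5-difluorophenyl in place of phenyl giving a 1.2-fold lower number from compound 1 to compound 4 (0.09 log units; within the scatter) and 3,5-difluorophenyl in place of 2-chlorophenyl giving a 1.4-fold lower number from compound 2 to compound 4 (0.15 log units; within the scatter). Every single-place change now available, at the double bond and on the aromatic group alike, therefore stays within the scatter in this series.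

The compounds shown leave open whether the double-bond geometry is equally silent with phenyl or 2-chlorophenyl on the oxime carbon, as each of those groups appears here in one geometry only. They also leave open what a methoxy group in place of the oxime hydroxyl, or a longer chain leading from the oxime carbon to the rest of the core, would do to the number.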